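A few compounds are considered here, and "the series" means these few. Any claim that something is new, unique, unknown or untested is made for them only; others in the source may bear on it.

Compound 1 `CN(O)/C=C\C(=O)c1ccc2ccccc2c1` was tested in an assay on RBL-1 cells for inhibition of Polyunsaturated fatty acid 5-lipoxygenase (Rattus norvegicus) (on this read-out lower numbers stand for stronger inhibition and higher numbers for weaker inhibition), and compound 1 gives 1800 nM. Compound 2 `O=C(/C=C\N(O)c1ccccc1)c1ccc2ccccc2c1` shares the same core, and in this assay compound 2 gives 810 nM. The structural change between them is methyl in place of phenyl on an amine nitrogen, and it produced a 2.2-fold higher number from compound 2 to compound 1 (0.35 log units; beyond the scatter). Compound 3 `O=C(/C=C\N(O)c1ccccc1)c1ccc(F)cc1` carries a different core; how its core differs from that of compound 2 is not broken down here. In this assay compound 3 gives 200 nM. Compound 4 `CN(O)/C=C\C(=O)c1ccc(F)cc1` is derived from compound 3 by the same change, (methyl in place of phenyl on an amine nitrogen), at the same place. Because the earlier step of a 2.2-fold higher number from compound 2 to compound 1 (0.35 log units; beyond the scatter) was modest, an expected step of a 2.3-fold higher number from compound 3 to compound 4 (0.35 log units; beyond the scatter) is estimated here. Compound 4 is therefore expected to give about 450 nM, most likely between 200 nM and 1000 nM.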

Compound 4, half-maximal inhibitory concentration: 5000 nM
Compound 4: middle estimate off by 11-fold (1.05 log units), on the low side, outside the stated range (above it).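

Putting methyl in place of phenyl on the amine nitrogen again weakens inhibition, now with a 25-fold higher number from compound 3 to compound 4 (1.40 log units; beyond the scatter), so the direction matches the earlier step but the size is much larger. The size of this change therefore did not carry over from one core to the other in this assay: the same change on two cores in this assay, a 2.2-fold higher number (0.35 log units; beyond the scatter) from compound 2 to compound 1 and a 25-fold higher number (1.40 log units; beyond the scatter) from compound 3 to compound 4, 11-fold (1.05 log units) apart, beyond the scatter of two such steps. These two pairs show that the core can strongly alter the effect of this change, but they do not show why, or what the change would do on a third core.

The compounds shown leave open how an ethyl or a benzyl group on that nitrogen would behave on either core. They also leave open whether the gap between the two cores would persist with such groups.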